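The source may report more compounds than this note shows. Statements on the series, on what has been measured and on what is new or still open speak of the compounds shown alone.

Measured in a functional assay on KB-VIN10 cells (Homo sapiens) for inhibition, with a stated time of 72 h; on this read-out higher numbers stand for weaker inhibition and lower numbers for stronger inhibition:
- compound 1 `COc1ccc(S(=O)(=O)N2CCc3cccc(-c4ccc(F)cc4)c32)cc1`: 94.6 nM
- compound 2 `COc1ccc(S(=O)(=O)N2CCc3cccc(-c4ccncc4)c32)cc1`: 106 nM

Going by the values given here, compound 2 lies within the scatter of compound 1, the only other number so far. Compound 3 `COc1ccc(S(=O)(=O)N2CCc3cccc(-c4ccc(O)cc4)c32)cc1` is the next case, and the change is 4-hydroxyphenyl in place of pyridin-4-yl on an aromatic carbon. Among the compounds with values here, one measured step bears on this place, a 1.1-fold higher number from compound 1 to compound 2 (0.05 log units; within the scatter), and it is small. No step beyond the scatter is therefore expected in this assay, although one step is thin evidence and no 4-hydroxyphenyl case has been measured. The expected step is a 1.0-fold lower number from compound 2 to compound 3 (0.00 log units; within the scatter). For compound 3 the estimated value is 105 nM, with an expected range of 40 nM to 280 nM.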

Compound 3, half-maximal inhibitory concentration: 123 nM
For compound 3 the middle estimate is 1.2-fold (0.07 log units) below the measured one, and the stated range covers the measured number.
By their numbers in this assay, from the lowest: compounds 1, 2 and 3 (each within the scatter of the next).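

The 4-hydroxyphenyl group brings a hydrogen-bond donor to this place, yet in this assay the step is a 1.2-fold higher number from compound 2 to compound 3 (0.06 log units; within the scatter). Hydroxy in place of fluoro gives a 1.3-fold higher number from compound 1 to compound 3 (0.11 log units; within the scatter), so all three compounds lie within the scatter of one another whether the aromatic ring carries fluoro, hydroxy or a ring nitrogen. No available evidence bears on this result.

Every group shown here is a six-membered aromatic ring. On these data alone, whether a saturated ring such as morpholine, or a phenyl ring bearing a carboxylic acid, would stay within the same scatter remains open.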